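The compounds below may be only part of what the source reports. "The series", "measured", "known", "first", "only" and "open" are said of these compounds alone.

Working notes on the series. For the measured compounds named here, compound 1 `CC(Oc1ccc(Oc2ccc(C(F)(F)F)cc2)cc1)C(=O)Cn1nnc(-c2ccccc2)n1` and compound 2 `COC(=O)c1ccc(-c2nnn(CC(=O)C(C)Oc3ccc(Oc4ccc(F)cc4)cc3)n2)cc1` share the same core and differ from each other in two places, so no single step can be drawn between them; only their two values can be set side by side. In an ADME assay on S9 fraction from liver (Rattus norvegicus) for metabolic stability, read by LC-MS, using NADPH, with a stated time of 30 min (a lower number here means that less of the compound is left, a higher number that more of the compound is left), compound 1 gives 6%. In this assay compound 2 gives < 5%, which is a limit of the method and not a number. Compound 2 therefore stands at the limit of < 5% in this assay, at which 1 of the 2 values shown sits. Both values of this pair lie at the low end of the scale.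

Compound 3 `COC(=O)c1ccc(-c2nnn(CC(=O)C(C)Oc3ccc(Oc4ccc(C(F)(F)F)cc4)cc3)n2)cc1` has not been measured. It differs from compound 2 by trifluoromethyl in place of fluoro on an aromatic carbon. Going by the values given here, no measured pair covers this change on its own, so there is no measured step to lean on. Starting from compound 2, which already sits at the limit, the step from compound 2 to compound 3 is expected to be no larger than the scatter, a number no lower from compound 2 to compound 3 (the limit leaves the size open). Compound 3 is accordingly estimated to give 5% in this assay, with a range from 0% to 12%, and with a real chance that again only the limit is reported.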

Compound 3, percent of the compound remaining: 15%
Estimate against measurement, compound 3: 10 percentage points below; the whole stated range lies below it.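

For the compounds shown here, on the aromatic carbon para to a large group, trifluoromethyl in place of fluoro gives, in this assay, a number at least 10 percentage points higher from compound 2 to compound 3 (that floor lies within the scatter), which is the first reading of this change. As far as these compounds go, compound 2 stands at a limit and not at a number, so this step has only a floor and its true size stays open: the limit of < 5% in this assay, at which 1 of the 3 values shown sits. Methoxycarbonyl in place of hydrogen on an aromatic carbon, which the first pair could not separate from the other difference, reads as a number 9 percentage points higher from compound 1 to compound 3 (within the scatter), so with trifluoromethyl held in place this group brings no shift beyond the scatter.

From the compounds shown here alone, it remains open whether the change from fluoro to trifluoromethyl has the same effect without methoxycarbonyl, and whether any replacement at this place can move the percent remaining beyond the scatter. A carboxylic acid or an amide in place of methoxycarbonyl, or a nitrile or chloro in place of trifluoromethyl, would extend both comparisons past the two changes read so far.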